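The source may report more compounds than this note shows. Statements on the series, on what has been measured and on what is new or still open speak of the compounds shown alone.

Among the compounds with values here, the three compounds measured so far share one core, and each of them has given only a limit in a toxicity assay on MDCK cells (Canis lupus familiaris) for cytotoxicity, read by crystal violet staining, with a stated time of 48 h; a lower number here means that less compound is tolerated, a higher number that more compound is tolerated. Compound 1, `Cc1ccc2cc(CN(Cc3ccc(F)cc3)Cc3ccc(C(C)C)cc3)c(=O)[nH]c2c1`, sits at a limit: in this assay compound 1 gives > 33000 nM. Compound 2, `Cc1ccc2cc(CN(Cc3ccc(C(C)C)cc3)Cc3cccc(F)c3)c(=O)[nH]c2c1`, sits at the same limit: in this assay compound 2 gives > 33000 nM. The step between them, a step that the two limits leave unreadable from compound 1 to compound 2, is therefore not readable. Compound 3, `CCCCOc1ccc(CN(Cc2ccc(C(C)(C)C)cc2)Cc2cc3cc(C)ccc3[nH]c2=O)cc1`, also stands at a limit, a different one: in this assay compound 3 gives > 5000 nM. Two of the three values sit at the limit of > 33000 nM in this assay, at which 2 of the 3 values shown sit, and one at the limit of > 5000 nM in this assay, at which 1 of the 3 values shown sits, so no measured number exists for any compound in this series.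

Compound 4, `Cc1ccc2[nH]c(=O)c(CN(Cc3ccc(C(C)(C)C)cc3)[C@@H](C)c3ccc(F)cc3)cc2c1`, differs from compound 3 in one place: 1-(4-fluorophenyl)ethyl in place of 4-butoxybenzyl on an amine nitrogen. Within the data shown here, no measured step bears on this change. Among the measured compounds shown here, the only step in hand, a step that the two limits leave unreadable from compound 1 to compound 2, concerns a fluorine position and its size cannot be read, while the value of compound 3 is a limit. No size or direction can be derived for the step to compound 4, and the expectation is simply that compound 4 too ends at a limit. Compound 4 is therefore expected to show 33000 nM in this assay, with a range from 10000 nM to 100000 nM. The step that the limit leaves unreadable from compound 3 to compound 4 is thus expected to be no more than the scatter, if a number is obtained at all.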

Compound 4, half-maximal cytotoxic concentration: > 5000 nM
Compound 4: a limit, no number (the forecaster's own chance of this, stated with the estimate: 80%); the middle value lies beyond the limit too.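

In this assay compound 4 gives > 5000 nM, which is a limit and not a number. Compound 3 also stands at a limit, so no step can be read between compound 3 and compound 4. The compounds shown leave open what concentration of any of them reaches the half-maximal cytotoxic effect, and whether the change on the amine nitrogen alters it.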